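The source may hold more compounds than are shown below. What is called first, only, known or untested is meant among the compounds shown, and "the series" means these compounds.

Measured in a functional assay on HepG2 cells (Homo sapiens) for antiproliferative activity, read by MTT assay, with a stated time of 48 h; on this read-out lower numbers stand for stronger inhibition and higher numbers for weaker inhibition:
- Compound 1 `O=c1cc(-c2ccccc2)oc2cc(OCc3ccccc3)c(OCCCN3CCCC3)c(O)c12`: 4200 nM
- Compound 2 `O=c1cc(-c2ccccc2)oc2cc(O)c(OCCCCN3CCCC3)c(O)c12`: > 100000 nM (a limit, not a number)

Compound 2 stands only as a limit: the limit of > 100000 nM in this assay, at which 1 of the 2 values shown sits. Compound 3 `O=c1cc(-c2ccccc2)oc2cc(O)c(OCCCN3CCCC3)c(O)c12` differs from compound 2 in one place: pyrrolidin-1-yl in place of (pyrrolidin-1-yl)methyl on a saturated chain carbon, three bonds along the chain from an oxygen on an aromatic ring. The chain thus goes from 4-(pyrrolidin-1-yl)butyl to 3-(pyrrolidin-1-yl)propyl. Among the compounds with values here, no measured step covers this change, so the expectation is loose. A moderate move towards stronger inhibition is expected in this assay, though a reading still at the limit remains possible. Compound 1, at 4200 nM, shows that measurable values occur in this series. The expected step is an at least 2.5-fold lower number from compound 2 to compound 3 (0.39 log units; beyond the scatter). The estimate for compound 3 is 40000 nM. The expected range for compound 3 runs from 10000 nM to 100000 nM.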

Compound 3, half-maximal inhibitory concentration: > 100000 nM
Compound 3: a limit, no number; the forecaster's own chance of this, stated with the estimate: 35%; middle value at least 2.5-fold (0.39 log units) away from the limit.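

Going from 4-(pyrrolidin-1-yl)butyl to 3-(pyrrolidin-1-yl)propyl yields no number in this assay, and the step between the two limits cannot be read: the limit of > 100000 nM in this assay, at which 2 of the 3 values shown sit.

Hydrogen in place of benzyl on an oxygen on an aromatic ring gives an at least 23-fold higher number from compound 1 to compound 3 (1.37 log units; beyond the scatter), the only readable step here, so in this pair the measurable value goes with the benzyl group.

Open, from the compounds shown here alone, is whether chain length changes the value with benzyl in place. Also open, going by these compounds, is whether methyl on that oxygen, or piperidine in place of pyrrolidine, keeps a measurable value.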